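This account rests on a few compounds, and the source may have more. Where it says the series, first, only, none or still open, it means among the compounds named here.

Measured compounds:
compound 1, `Oc1ccccc1CNc1ccc(-c2ccc(F)cc2)cc1`: 3860 nM
compound 2, `Oc1ccccc1CNc1ccc(-c2ccc(Cl)cc2)cc1`: 2390 nM
compound 3, `COc1ccc(-c2ccc(NCc3ccccc3O)cc2)cc1`: 580 nM

Three compounds share one core and differ only in the group at the far end of the outer aromatic ring. In a functional assay on Jurkat cells (Homo sapiens) for activation, with a stated time of 24 h (on this read-out lower numbers stand for an effect already at smaller amounts and higher numbers for an effect only at larger amounts of compound), compound 1 gives 3860 nM. Compound 2 gives 2390 nM. Compound 3 gives 580 nM and stands lowest of the three numbers, since a 6.7-fold lower number from compound 1 to compound 3 (0.82 log units; beyond the scatter) and a 4.1-fold lower number from compound 2 to compound 3 (0.61 log units; beyond the scatter), both beyond the scatter. Between the two halogen compounds, a 1.6-fold lower number from compound 1 to compound 2 (0.21 log units; within the scatter), so those two cannot be ordered.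

Compound 4, `Oc1ccccc1CNc1ccc(-c2ccc(OC(F)(F)F)cc2)cc1`, is not yet measured. It differs from compound 3 by trifluoromethyl in place of methyl on an oxygen on an aromatic ring. Among the measured compounds shown here, no measured step touches the methyl on that oxygen; the only steps that bear on the place are the halogen-to-methoxy replacements, a 6.7-fold lower number from compound 1 to compound 3 (0.82 log units; beyond the scatter) and a 4.1-fold lower number from compound 2 to compound 3 (0.61 log units; beyond the scatter), which show that the group at this position can shift this assay by a modest amount. Compound 4 is therefore expected to move away from compound 3 in the direction of compound 1 and compound 2, with wide uncertainty. Compound 4 is expected to give 1500 nM, within a range from 450 nM to 5000 nM. This corresponds to an expected step of a 2.6-fold higher number from compound 3 to compound 4 (0.41 log units; beyond the scatter).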

Compound 4, half-maximal effective concentration: "not active" (no number reported)
The entry for compound 4 holds no number, so the estimate cannot be set against anything.
By their numbers in this assay, from the lowest: compound 3; then compounds 2 and 1 (each within the scatter of the next).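

Among the compounds shown here, compound 4 is recorded as "not active" in this assay, with no number, so no step from compound 3 to compound 4 can be read. Nothing shown gives a reason for this result.

The compounds shown leave open how large the change from methoxy to trifluoromethoxy is.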